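Compound 3 to compound 4: acetoxy to hydroxy

The source may hold more compounds than are shown below. What is called first, only, known or untested is meant among the compounds shown, and "the series" means these compounds.

In an ADME assay on PA-1 cells (Homo sapiens) for cytotoxicity, read by MTT assay, with a stated time of 72 h (a higher number here means a weaker inhibitor, a lower number a stronger inhibitor), compound 3 (`COc1ccc(C2=C(c3cc(OC)c(OC)c(OC)c3)C(=O)C(OC(C)=O)C2)cc1F`) gives > 100 ug/mL, a limit and not a number. Compound 4 (`COc1ccc(C2=C(c3cc(OC)c(OC)c(OC)c3)C(=O)C(O)C2)cc1F`) replaces acetoxy with hydroxy, hydrogen in place of acetyl on an oxygen on a saturated carbon. For the measured compounds named here, no measured step covers this change. The only one, a step that the two limits leave unreadable from compound 1 to compound 2, is a different exchange and has no readable size. Like compound 4, compound 1 (`C=CCOc1cc(C2=C(c3cc(OC)c(OC)c(OC)c3)C(=O)C(O)C2)ccc1OC`) carries the hydroxy, and compound 1 gives > 100 ug/mL, also a limit. Compound 2 (`COc1ccc(C2=C(c3cc(OC)c(OC)c(OC)c3)C(=O)C(O)C2)cc1NC(=O)c1ccccc1`) carries it too, and compound 2 gives > 100 ug/mL, again a limit. The picture so far is the limit of > 100 ug/mL in this assay, at which 3 of the 3 values shown sit. No change beyond the scatter is expected, so the estimated step is a number no higher from compound 3 to compound 4 (the limit leaves the size open). Compound 4 is expected at 100 ug/mL, with an estimated range of 40 ug/mL to 200 ug/mL.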

Compound 4, half-maximal inhibitory concentration: > 100 ug/mL
Compound 4 was reported as a limit; the forecaster's own chance of this, stated with the estimate: 75%; the middle value lies on the limit itself.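

For the compounds shown here, no step among compound 1, compound 2, compound 3 and compound 4 can be read in this assay, as each result is a limit and not a number: the limit of > 100 ug/mL in this assay, at which 4 of the 4 values shown sit. The compounds shown leave open whether any of these exchanges alters cytotoxicity, and by how much.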